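This account rests on a few compounds, and the source may have more. Where it says the series, first, only, none or still open, it means among the compounds named here.

Measured so far in a functional assay on HeLa cells (Homo sapiens) for antiproliferative activity, read by MTT assay, with a stated time of 48 h; a lower number here means a stronger inhibitor, a higher number a weaker inhibitor:
- compound 1, `COc1ccc(-c2cncc3[nH]c(=O)n(Cc4cc(OC)c(OC)c(OC)c4)c23)cc1O`: > 20000 nM (a limit of the assay, not a number)
- compound 2, `COc1ccc(-c2cc3c(cn2)n(C)c(=O)n3-c2cc(OC)c(OC)c(OC)c2)cc1O`: 2220 nM

Compound 1 sits at the limit of this assay, recorded as the limit of > 20000 nM in this assay, at which 1 of the 2 values shown sits, so it yields only a bound and no number. Among the compounds with values here, compound 2 is therefore the only compound in the pair with a measured number in this assay, and it stands as the sole reference point; the two structures differ in more than one place, so no single step between them is counted, and their values show only that compound 2 has a number where compound 1 has none.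

Compound 3, `COc1ccc(-c2cc3c(cn2)n(C2CC2)c(=O)n3-c2cc(OC)c(OC)c(OC)c2)cc1O`, is the next entry, not yet measured. Relative to compound 2 it differs by cyclopropyl in place of methyl on an aromatic nitrogen. Within the data shown here, no step between measured compounds exists to guide the size of this change. Without a measured comparison of this kind in the series, the expected step from compound 2 is small, in no particular direction, and not beyond the scatter: the estimated step is a 1.1-fold lower number from compound 2 to compound 3 (0.05 log units; within the scatter). Compound 3 is thus expected to give about 2000 nM in this assay, in a range from 700 nM to 6000 nM.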

Compound 3, half-maximal inhibitory concentration: > 20000 nM
Compound 3: a limit, no number (the forecaster's own chance of this, stated with the estimate: 5%); at least 10-fold (1.00 log units) between middle value and limit.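

In this assay, the position on the aromatic nitrogen of the five-membered ring proves sensitive to the group it carries, something compounds 1 and 2 could not show: cyclopropyl in place of methyl gives an at least 9.0-fold higher number from compound 2 to compound 3 (0.95 log units; beyond the scatter). Compound 3 gives > 20000 nM, which is a limit of the assay and not a number. The change is small when counted, with 1 heavy atom leaving and 3 heavy atoms entering and no hydrogen-bond donor or acceptor on either side, yet it removes the measured number, leaving compound 2 as the only compound in the series with one: the limit of > 20000 nM in this assay, at which 2 of the 3 values shown sit.

As far as these compounds go, how far compound 3 lies past the limit stays unknown, so the step has a bound and no fixed size. From the compounds shown here alone, whether the loss goes with the three-membered ring or simply with the added carbons also stays open, as does whether an ethyl or isopropyl group, or an aminoethyl chain, on this nitrogen would keep a measurable value in this assay.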